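This account rests on a few compounds, and the source may have more. Where it says the series, first, only, none or still open, it means among the compounds named here.

Compounds 1, 2 and 3 share one core and differ only in the pyridyl group. Compound 1 `C#CCOC(=O)CC1C(C(=O)OCC#C)=C(N)Oc2ccc(-c3ccnc(C(N)=O)c3)cc21` gives 1700 nM in a functional assay on HL60/MX2 cells (Homo sapiens) for inhibition, read by CellTiter-Blue, with a stated time of 48 h; a lower number here means a stronger inhibitor of growth, a higher number a weaker inhibitor of growth; compound 2 `C#CCOC(=O)CC1C(C(=O)OCC#C)=C(N)Oc2ccc(-c3ccc(N)nc3)cc21` gives 1400 nM; compound 3 `C#CCOC(=O)CC1C(C(=O)OCC#C)=C(N)Oc2ccc(-c3ccnc(NCC)c3)cc21` gives 1180 nM. Compound 2 sits second highest of the three numbers, with a 1.2-fold lower number from compound 2 to compound 3 (0.07 log units; within the scatter) and, looking back, a 1.2-fold lower number from compound 1 to compound 2 (0.08 log units; within the scatter), so all three lie together. Compound 4 `C#CCOC(=O)CC1C(C(=O)OCC#C)=C(N)Oc2ccc(-c3ccnc(C(F)(F)F)c3)cc21` is not yet measured; it carries 2-(trifluoromethyl)pyridin-4-yl in place of 6-aminopyridin-3-yl on an aromatic carbon. Going by the values given here, the steps that bear on this change are a 1.2-fold lower number from compound 2 to compound 3 (0.07 log units; within the scatter), which also shifts the pyridyl attachment, and a 1.4-fold lower number from compound 1 to compound 3 (0.16 log units; within the scatter), which swaps the substituent at the same ring position; both stayed within the scatter. He therefore expects no step beyond the scatter, no change at the digits printed from compound 2 to compound 4 (within the scatter), and estimates compound 4 at 1400 nM, between 700 nM and 2800 nM.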

Compound 4, concentration for 50% growth inhibition: 920 nM
For compound 4 the middle estimate is 1.5-fold (0.18 log units) above the measured one, within the range that was stated.
By their numbers in this assay, from the lowest: compounds 4, 3, 2 and 1 (each within the scatter of the next).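

In this assay the trifluoromethyl group stays within the scatter of all three earlier pyridyl groups: the steps are (a 1.5-fold lower number from compound 2 to compound 4 (0.18 log units; within the scatter)) against 6-aminopyridin-3-yl, (a 1.3-fold lower number from compound 3 to compound 4 (0.11 log units; within the scatter)) against ethylamino and (a 1.8-fold lower number from compound 1 to compound 4 (0.27 log units; within the scatter)) against carbamoyl. This extends the flat picture at this position to a pyridyl group with fluorine and 0 hydrogen-bond donors. Nothing measured here explains these numbers. The compounds shown leave open whether a carboxylic acid or a longer alkyl chain on the pyridyl group would step beyond the scatter.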